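Lengthening the propyl chain of compound 1 to butyl

A few compounds are considered here, and "the series" means these few. Any claim that something is new, unique, unknown or untested is made for them only; others in the source may bear on it.

Of the compounds shown here, two have been measured so far, compound 1 (`CCCN(c1ccc(OC)cc1)c1ncnc2occ(C)c12`) and compound 2 (`CSc1ccc(N(C)c2ncnc3occ(C)c23)cc1`). In a functional assay on MDA-MB-435 cells (Homo sapiens) for inhibition, read by sulforhodamine B assay, with a stated time of 48 h (on this read-out higher numbers stand for an effect only at larger amounts of compound and lower numbers for an effect already at smaller amounts), compound 1 gives 27.3 nM and so holds the higher of the two numbers, while compound 2 gives 12.3 nM and lies beyond the usual scatter from it. These two compounds differ in more than one place, so their gap isolates no single change.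

Compound 3 (`CCCCN(c1ccc(OC)cc1)c1ncnc2occ(C)c12`) keeps the core of compound 1 and alters only its chain (methyl in place of hydrogen on a saturated chain carbon, three bonds along the chain from a nitrogen on an aromatic ring), with methyl in place of hydrogen on a saturated chain carbon, three bonds along the chain from a nitrogen on an aromatic ring. This turns propyl to butyl. Going by the values given here, no measured pair shows what such a change does, so the expectation is a cautious one: a modest move towards a higher number in this assay, possibly not far beyond the scatter. The estimated step of a 2.0-fold higher number from compound 1 to compound 3 (0.30 log units; within the scatter) is expected to be of that size. For compound 3 the expected value is 55 nM with an estimated range from 18 nM to 170 nM in this measurement.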

Compound 3, half-maximal effective concentration: 100 nM
Compound 3: middle estimate off by 1.8-fold (0.26 log units), on the low side; measured number inside the range.
By their numbers in this assay, from the lowest: compound 2; then compound 1; then compound 3.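

In this assay, going by these compounds alone, the change from propyl to butyl gives the first reading of this position, with a 3.7-fold higher number from compound 1 to compound 3 (0.56 log units; beyond the scatter). Methyl in place of hydrogen on a saturated chain carbon, three bonds along the chain from a nitrogen on an aromatic ring, therefore moves the number beyond the usual scatter, towards an effect only at larger amounts of compound, so the chain of compound 1 does not tolerate this lengthening without a measurable change on this read-out. The data offer no explanation for this shift.

Going by these compounds, a single step does not show whether the number keeps rising along the chain, and it remains open whether a pentyl chain would carry the rise further, whether an ethyl chain would give a lower number than compound 1, and how a branched isobutyl chain or a hydroxyl group at the end of the butyl chain would read. On these data alone, it also remains open whether the same lengthening would have a similar effect in a compound carrying the methylthio group of compound 2 in place of the methoxy group of compound 1.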